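From 3,5-dimethylphenyl to 4-ethylphenyl on the shared core

This account rests on a few compounds, and the source may have more. Where it says the series, first, only, none or still open, it means among the compounds named here.

Compound 1 `CC1=C(O)c2c(oc(-c3ccccc3C)cc2=O)C(C)(C)C1=O` gives 37.3 ug/mL
Compound 2 `CC1=C(O)c2c(oc(-c3cc(C)cc(C)c3)cc2=O)C(C)(C)C1=O` gives 53.1 ug/mL

In a functional assay on KB cells (Homo sapiens) for cytotoxicity, read by sulforhodamine B assay (on this read-out higher numbers stand for an effect only at larger amounts of compound and lower numbers for an effect already at smaller amounts), compound 2 gives 53.1 ug/mL and sits within the scatter of compound 1 at 37.3 ug/mL with neither ranked ahead. The change 4-ethylphenyl in place of 3,5-dimethylphenyl on an aromatic carbon puts 4-ethylphenyl in place of 3,5-dimethylphenyl on an aromatic carbon and turns compound 2 into compound 3 `CCc1ccc(-c2cc(=O)c3c(o2)C(C)(C)C(=O)C(C)=C3O)cc1` with the core untouched. Among the compounds with values here, the only measured step of a 1.4-fold higher number from compound 1 to compound 2 (0.15 log units; within the scatter) also swapped one substituted phenyl group for another and stayed within the scatter. So no step beyond the scatter is expected in this assay for this change. The expected 1.2-fold lower number from compound 2 to compound 3 (0.07 log units; within the scatter) is small. Compound 3 is estimated at 45 ug/mL with 20 ug/mL to 95 ug/mL as the expected range.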

Compound 3, concentration for half-maximal effect: 20 ug/mL
Compound 3: the middle estimate sits 2.3-fold (0.35 log units) above what was measured, within the range that was stated.
By their numbers in this assay, from the lowest: compounds 3, 1 and 2 (each within the scatter of the next, the first and the last beyond it).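

In this assay, the arrangement of the same atoms on this aromatic carbon can matter: unlike the step between the two earlier compounds, 4-ethylphenyl in place of 3,5-dimethylphenyl goes beyond the scatter (a 2.7-fold lower number from compound 2 to compound 3 (0.42 log units; beyond the scatter)). Against 2-methylphenyl, however, 4-ethylphenyl stays within the scatter (a 1.9-fold lower number from compound 1 to compound 3 (0.27 log units; within the scatter)), so compound 3 is clearly separated only from compound 2. No measurement here gives a reason for this difference. As far as these compounds go, it remains open whether a longer chain in place of ethyl, or an amine or carboxylic acid on the phenyl ring, would shift the number further.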